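The compounds below may be only part of what the source reports. "The series", "measured", "known", "first", "only" and "open" are said of these compounds alone.

Of the compounds shown here, three built on one shared core have been measured in a functional assay on CNS cells (Homo sapiens) for antiproliferative activity; on this read-out higher numbers stand for weaker inhibition of growth and lower numbers for stronger inhibition of growth. Compound 1 `Cc1sc2nc(-c3ccccn3)c(/C=N/NC(=N)N)n2c1C` gives 41700 nM, compound 3 `Cc1cn2c(/C=N/NC(=N)N)c(-c3ccccn3)nc2s1` gives 26900 nM, and compound 2 `N=C(N)N/N=C/c1c(-c2ccccn2)nc2sc(Cl)cn12` gives 11500 nM, the lowest of the three numbers. The step of a 1.6-fold lower number from compound 1 to compound 3 (0.19 log units; within the scatter) and the step of a 2.3-fold higher number from compound 2 to compound 3 (0.37 log units; beyond the scatter) both concern the small group on the five-membered ring. Compound 4 `N=C(N)N/N=C/c1c(-c2cccnc2)nc2sc(Cl)cn12` changes something else: pyridin-3-yl in place of pyridin-2-yl on an aromatic carbon. Among the compounds with values here, no measured step touches the pyridin-2-yl group, so neither the direction nor the size of this change can be read from the steps at hand, and the expectation is only that compound 4 lands near compound 2 with wide uncertainty. Compound 4 is therefore estimated at 15000 nM, between 5000 nM and 50000 nM. This corresponds to an expected step of a 1.3-fold higher number from compound 2 to compound 4 (0.12 log units; within the scatter).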

Compound 4, concentration for total growth inhibition: 31600 nM
Beside the measured number, compound 4's estimate is 2.1-fold (0.32 log units) below it, and the stated range covers the measured number.
By their numbers in this assay, from the lowest: compound 2; then compounds 3, 4 and 1 (each within the scatter of the next).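

In this assay the swap of pyridin-2-yl for pyridin-3-yl gives a 2.7-fold higher number from compound 2 to compound 4 (0.44 log units; beyond the scatter) and so shows that this position responds to how the pyridine ring is attached, even though both groups hold the same atoms. Within the data shown here, the earlier steps touched only the small group on the five-membered ring, so this is the first sign that the aromatic group on this carbon matters too. Nothing at hand gives a reason for this shift. Open remains how a phenyl or pyridin-4-yl group would fare here, and whether the same swap would act alike with methyl in place of chloro.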